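Alkyl size on the benzylic amine and serotonin receptor binding

This account rests on a few compounds, and the source may have more. Where it says the series, first, only, none or still open, it means among the compounds named here.

Compound 1, `CCCN(CCC)Cc1ccc(Cl)c(-c2ccccc2OC)c1`, gave > 10000 nM in an assay on isolated protein for binding affinity to 5-hydroxytryptamine receptor 1E (Homo sapiens) (on this read-out higher numbers stand for weaker inhibition and lower numbers for stronger inhibition), which is a limit of the assay rather than a number.
Compound 2, `CNCc1ccc(Cl)c(-c2ccccc2OC)c1`, gave 2400 nM in this assay.
Compound 3, `CCNCc1ccc(Cl)c(-c2ccccc2OC)c1`, has not yet been measured in this assay.

Going by the values given here, compound 2 therefore holds the only actual number in this assay; the other entry is a limit. Among the compounds with values here, the single measured comparison is an at least 4.1-fold lower number from compound 1 to compound 2 (0.61 log units; beyond the scatter), and because it rests on the limit of > 10000 nM in this assay, at which 1 of the 2 values shown sits, its true size is open-ended. Compound 3 differs from compound 2 by methyl in place of hydrogen on a saturated chain carbon bound to an amine nitrogen. This move partly reverses the measured shortening, taking the amine substituent from methyl toward the dipropylamino of compound 1, and one methyl is a small part of that measured change. A step in the direction of weaker binding is therefore expected, but only a modest one, and it may not exceed the scatter. Compound 3 is expected to give about 3500 nM in this assay, within a range from 1500 nM to 9000 nM. That estimate corresponds to an expected step of a 1.5-fold higher number from compound 2 to compound 3 (0.16 log units; within the scatter).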

Compound 3, inhibition constant: > 10000 nM
Compound 3: no number, only a limit (the forecaster's own chance of this, stated with the estimate: 15%); middle value at least 2.8-fold (0.45 log units) from the limit.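

In this assay, methyl in place of hydrogen on a saturated chain carbon bound to an amine nitrogen, which turns methylamino into ethylamino, gives an at least 4.1-fold higher number from compound 2 to compound 3 (0.61 log units; beyond the scatter). The earlier comparison, an at least 4.1-fold lower number from compound 1 to compound 2 (0.61 log units; beyond the scatter), spanned the whole change from dipropylamino to methylamino and could not show how much of it a single methyl accounts for; this one shows that such a small addition already moves the value beyond the scatter and up to the assay limit, so that among the compounds shown only compound 2, with methylamino, holds an actual number. Going by these compounds, the true size of this step remains open-ended, and the step between compound 1 and compound 3 cannot be read, because both of these entries are limits rather than numbers: the limit of > 10000 nM in this assay, at which 2 of the 3 values shown sit.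

The compounds shown leave open how a primary amine, with no alkyl group on the nitrogen, or a dimethylamino group would stand in this assay. They also leave open whether a cyclopropyl group or a longer chain on the nitrogen would stay at the same limit.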